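Ethynyl for Isopropyl: Cytotoxicity Outlook for Compound 4

The source may report more compounds than this note shows. Statements on the series, on what has been measured and on what is new or still open speak of the compounds shown alone.

Compound 1, `Cc1ccc(S(=O)(=O)N[C@@H](CC(=O)NC(C)(C)C)C(=O)NCCNC(=O)c2cccc(C(C)C)c2)cc1`, gives in an ADME assay on Karpas-1106P cells (Homo sapiens) for cytotoxicity (on this read-out higher numbers stand for an effect only at larger amounts of compound and lower numbers for an effect already at smaller amounts), only the limit > 11100 nM.
Compound 2, `Cc1ccc(S(=O)(=O)N[C@@H](CC(=O)NC(C)(C)C)C(=O)NCCNC(=O)NCc2ccccc2)cc1`, gives in this assay only the limit > 11100 nM.
Compound 3, `Cc1ccc(S(=O)(=O)N[C@@H](CC(=O)NC(C)(C)C)C(=O)NCCNC(=O)c2cc(C)ccc2F)cc1`, gives in this assay only the limit > 11100 nM.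

Compound 1 therefore stands at the limit of this assay, with no number of its own. Compound 4, `C#Cc1cccc(C(=O)NCCNC(=O)[C@H](CC(=O)NC(C)(C)C)NS(=O)(=O)c2ccc(C)cc2)c1`, differs from it in one place: ethynyl in place of isopropyl on an aromatic carbon. The measured steps a step that the two limits leave unreadable from compound 1 to compound 2, a step that the two limits leave unreadable from compound 1 to compound 3 and a step that the two limits leave unreadable from compound 2 to compound 3 bear on this change only loosely, and none of them has a readable size because every value sits at the limit of > 11100 nM in this assay, at which 3 of the 3 values shown sit. No direction beyond the scatter can be drawn from them. Compound 4 is expected to behave like the others and to stay at the limit, with an estimated 20000 nM, ranging from 8000 nM to 60000 nM. The step this estimate means is a step that the limit leaves unreadable from compound 1 to compound 4, expected as no change beyond the scatter.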

Compound 4, half-maximal effective concentration: > 11100 nM
Compound 4: no number, only a limit (the forecaster's own chance of this, stated with the estimate: 85%); the middle value lies beyond the limit too.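

In this assay, within the data shown here, compound 4, like compound 1, compound 2 and compound 3, gives only a limit, so no step among them can be read: the limit of > 11100 nM in this assay, at which 4 of the 4 values shown sit. These compounds leave open at what concentration any of them would affect these cells.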